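Halogen exchange at the aromatic carbon: step to compound 3

The source may report more compounds than this note shows. Statements on the series, on what has been measured and on what is new or still open speak of the compounds shown alone.

compound 1 `CC1(C)N=C(N)N=C(N)N1c1ccccc1F` — 4.74
compound 2 `CC1(C)N=C(N)N=C(N)N1c1ccccc1Cl` — 4.15

Among the measured compounds shown here, in an assay for inhibition of Dihydrofolate reductase (Rattus norvegicus) (a lower number here means a less potent compound, a higher number a more potent compound, by a factor of ten per unit of this negative logarithm), compound 2 stands lowest of the two numbers; the only other measured value lies higher, a number 0.59 log units lower from compound 1 to compound 2 (beyond the scatter). Compound 3 `CC1(C)N=C(N)N=C(N)N1c1ccccc1I` differs from compound 2 by iodo in place of chloro on an aromatic carbon. For the measured compounds named here, the single measured step that bears on this change is a number 0.59 log units lower from compound 1 to compound 2 (beyond the scatter), a modest drop on exchanging one halogen for a heavier one at the same aromatic carbon. A second exchange of that kind is expected to lower the number again, though with wide uncertainty. Compound 3 is therefore estimated at 3.9 (range 3.2 to 4.6), an expected step of a number 0.25 log units lower from compound 2 to compound 3 (within the scatter).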

Compound 3, logarithm of the reciprocal of the active concentration, log(1/C): 4.62
Compound 3: middle estimate off by 0.72 log units, on the low side, and the stated range ends below it.
By their numbers in this assay, from the lowest: compound 2; then compounds 3 and 1 (each within the scatter of the next).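

In this assay the heavier halogen no longer goes with a lower number: a number 0.47 log units higher from compound 2 to compound 3 (beyond the scatter), which reverses the direction of the earlier step, while a number 0.12 log units lower from compound 1 to compound 3 (within the scatter), so fluoro and iodo cannot be told apart at this aromatic carbon. Compound 2 is thus the least potent of the three, and the order does not follow the sequence of the halogens. No measurement at hand accounts for this dip at chloro.

The compounds shown leave open whether chloro is a lone low point or whether non-halogen groups on this carbon, such as methyl, methoxy or an amine, would match fluoro and iodo.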